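The source may hold more compounds than are shown below. What is called first, only, known or untested is meant among the compounds shown, and "the series" means these compounds.

Compound 1 `CCN(c1ccc(C#N)c(Cl)c1)c1cc(-c2ccoc2)ccc1C`: > 30000 nM in a functional assay on PC-3 cells (Homo sapiens) for antiproliferative activity, read by CCK-8 assay, with a stated time of 6 days (a higher number here means a weaker inhibitor, a lower number a stronger inhibitor), a limit of the assay and not a number.
Compound 2 `N#Cc1ccc(N2CCCc3c(-c4ccncc4)cccc32)cc1C(F)(F)F`: 28700 nM.

Compound 1 thus stands at the limit of > 30000 nM in this assay, at which 1 of the 2 values shown sits, so only a limit is known for it. Compound 3 `CCN(c1ccc(C#N)c(Cl)c1)c1cc(-n2cccn2)ccc1C` differs from compound 1 by 1H-pyrazol-1-yl in place of furan-3-yl on an aromatic carbon. Within the data shown here, no measured pair shows such a change, so no step size can be drawn from the data, and the expected step from compound 1 to compound 3 in this assay is none beyond the scatter, in no settled direction. Compound 3 is therefore estimated at 30000 nM, within 8000 nM to 100000 nM. The step this estimate means is expected to be a number no higher from compound 1 to compound 3 (the limit leaves the size open).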

Compound 3, half-maximal inhibitory concentration: 15700 nM
For compound 3 the middle estimate is 1.9-fold (0.28 log units) above the measured one; the range from low to high includes it.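

In this assay compound 3 gives 15700 nM, so the core of compound 1 now has a number rather than a limit when 1H-pyrazol-1-yl sits on this aromatic carbon. For compound 1 the value is a limit of the assay and not a number: the limit of > 30000 nM in this assay, at which 1 of the 3 values shown sits. Exchanging furan-3-yl for 1H-pyrazol-1-yl at this position therefore gives an at least 1.9-fold lower number from compound 1 to compound 3 (0.28 log units; that floor lies within the scatter).

Going by these compounds, the real size of this step stays open, and it cannot be told whether the change goes beyond the scatter. Also open, on these data alone, is how an amine or a carboxylic acid on the same aromatic carbon would read in this assay.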